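Halogen swap on the pyridine-fused core: bromo to fluoro

This account rests on a few compounds, and the source may have more. Where it says the series, first, only, none or still open, it means among the compounds named here.

Three compounds of the series carry the same core and differ only at one aromatic carbon. Compound 1 `c1cnc2[nH]c(C[C@H]3CCCN3)cc2c1` gives 125 nM in an assay on membranes from brain for displacement of a labelled ligand from Neuronal acetylcholine receptor; alpha4/beta2 (Rattus norvegicus); on this read-out higher numbers stand for weaker inhibition and lower numbers for stronger inhibition. Compound 2 `Clc1ccc2cc(C[C@H]3CCCN3)[nH]c2n1` gives 147 nM, and compound 3 `Brc1ccc2cc(C[C@H]3CCCN3)[nH]c2n1` gives 691 nM, the highest number of the three. The step of a 1.2-fold higher number from compound 1 to compound 2 (0.07 log units; within the scatter) is small, whereas a 5.5-fold higher number from compound 1 to compound 3 (0.74 log units; beyond the scatter) and a 4.7-fold higher number from compound 2 to compound 3 (0.67 log units; beyond the scatter) are modest increases, so bromo stands apart from both hydrogen and chloro.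

Compound 4 `Fc1ccc2cc(C[C@H]3CCCN3)[nH]c2n1` is not yet measured. Its change from compound 3 is fluoro in place of bromo on an aromatic carbon. Going by the values given here, the steps that bear on it are a 4.7-fold higher number from compound 2 to compound 3 (0.67 log units; beyond the scatter) and a 5.5-fold higher number from compound 1 to compound 3 (0.74 log units; beyond the scatter), both modest. Because hydrogen and chloro lie close together while bromo in compound 3 gives the higher number 691 nM, fluoro is expected to land near the numbers of compound 1 and compound 2 rather than near compound 3, meaning a decrease of a 4.3-fold lower number from compound 3 to compound 4 (0.64 log units; beyond the scatter) beyond the scatter. Compound 4 is therefore estimated at 160 nM, with a range from 60 nM to 450 nM.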

Compound 4, inhibition constant: 316 nM
For compound 4 the middle estimate is 2.0-fold (0.30 log units) below the measured one; the range from low to high includes it.
By their numbers in this assay, from the lowest: compounds 1 and 2 (each within the scatter of the next); then compound 4; then compound 3.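

Fluoro on this aromatic carbon, next to the ring nitrogen, gives a third level in this assay: the number falls on leaving bromo (a 2.2-fold lower number from compound 3 to compound 4 (0.34 log units; beyond the scatter)) yet stays apart from chloro (a 2.1-fold higher number from compound 2 to compound 4 (0.33 log units; beyond the scatter)) and from hydrogen (a 2.5-fold higher number from compound 1 to compound 4 (0.40 log units; beyond the scatter)). The numbers at this position therefore do not follow the order fluoro, chloro, bromo, since chloro, not fluoro, stays within the scatter of hydrogen, while compound 3 and compound 4 both lie beyond it. No measurement is available that accounts for this ordering.

Going by these compounds, whether a methyl, a methoxy or an amino group on this carbon would stay with hydrogen and chloro or move towards bromo remains open. Also open, on these data alone, is whether the same halogen order holds on the other aromatic carbons of the shared core.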